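A benzoylethenyl swap at the edge of the assay

The source may hold more compounds than are shown below. What is called first, only, known or untested is meant among the compounds shown, and "the series" means these compounds.

Compound 3 `CCOC(=O)/C(C)=C/c1cc(/C=C/[C@](C)(/C=C/c2ccc(OC)cc2)CCC=C(C)C)ccc1O` was tested in a functional assay on Raji cells (Homo sapiens) for cytotoxicity, with a stated time of 72 h; a higher number here means that more compound is needed for the effect, a lower number that less compound is needed. Compound 3 gives > 26000 nM, which is a limit of the assay and not a number. Compound 2 `C=C[C@@](C)(/C=C/c1ccc(O)c(/C=C(\C)C(=O)OCC)c1)CCC=C(C)C` gives > 26000 nM, also a limit. Compound 1 `C=C[C@@](C)(/C=C/c1ccc(O)c(/C=C/C(=O)c2ccccc2)c1)CCC=C(C)C` gives > 26000 nM, again a limit. The whole series therefore stands at one mark: the limit of > 26000 nM in this assay, at which 3 of the 3 values shown sit.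

Compound 4 `COc1ccc(/C=C/[C@@](C)(/C=C/c2ccc(O)c(/C=C/C(=O)c3ccccc3)c2)CCC=C(C)C)cc1` has not yet been measured. It differs from compound 3 on an aromatic carbon, ortho to a hydroxy group, where 2-benzoylethenyl takes the place of 2-(ethoxycarbonyl)prop-1-en-1-yl: 2-benzoylethenyl in place of 2-(ethoxycarbonyl)prop-1-en-1-yl on an aromatic carbon.

For the measured compounds named here, the one measured single change is a step that the two limits leave unreadable from compound 2 to compound 3. It lies at a different place, where 2-(4-methoxyphenyl)ethenyl replaces vinyl, and its size cannot be read. The closer hint is compound 1, which already carries 2-benzoylethenyl and gives > 26000 nM, a limit. Going by the values given here, nothing measured so far therefore points to a real gain or loss in this assay, and compound 4 will most likely report only a limit as well. The expected outcome is a step that the limit leaves unreadable from compound 3 to compound 4, with no change beyond the scatter. For compound 4 the estimated value is 30000 nM, with an expected range from 12000 nM to 60000 nM.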

Compound 4, half-maximal effective concentration: > 26000 nM
Compound 4: no number, only a limit; the forecaster's own chance of this, stated with the estimate: 80%; the middle value does not contradict the limit.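

Compound 4 gives > 26000 nM, a limit of the assay and not a number, so no new step can be read from compound 3 or from compound 1 to compound 4. The compounds shown leave open whether either change has any effect in this assay, and how the four compounds compare with one another: the limit of > 26000 nM in this assay, at which 4 of the 4 values shown sit.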